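The source may hold more compounds than are shown below. What is called first, only, known or untested is meant among the compounds shown, and "the series" means these compounds.

Compound 1, with the structure `c1cc(-c2nccs2)c2c(c1)C(c1ncc[nH]1)CC2`, is the starting point. For the measured compounds named here, in a functional assay on CHO cells for agonist activity at Alpha-1D adrenergic receptor (Homo sapiens), read by FLIPR and calcium flux (a higher number here means that more compound is needed for the effect, a lower number that less compound is needed), compound 1 gives 3190 nM, and this is the only actual number among the three compounds measured so far. Compound 2, with the structure `CCS(=O)(=O)Nc1cccc2c1CCC2c1ncc[nH]1`, reaches only > 10000 nM in this assay, which is a limit rather than a number. Compound 3, with the structure `c1ccc(-c2cccc3c2CCC3c2ncc[nH]2)nc1`, likewise gives > 10000 nM in this assay, again a limit. Both of these compounds keep the core of compound 1 and differ from it at a single aromatic carbon: the step from compound 1 to compound 2 is an at least 3.1-fold higher number from compound 1 to compound 2 (0.49 log units; beyond the scatter), and the step from compound 1 to compound 3 is an at least 3.1-fold higher number from compound 1 to compound 3 (0.49 log units; beyond the scatter). The shared feature of these two steps is the limit of > 10000 nM in this assay, at which 2 of the 3 values shown sit.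

Compound 4, with the structure `c1cc(-c2ccn[nH]2)c2c(c1)C(c1ncc[nH]1)CC2`, makes a change at that same aromatic carbon: 1H-pyrazol-5-yl in place of 1,3-thiazol-2-yl on an aromatic carbon. Both earlier replacements of the 1,3-thiazol-2-yl group went beyond the scatter toward a higher number, so a weaker outcome is expected here too, and a limit is a real possibility. Compound 4 is therefore expected to give about 8000 nM, most likely between 2500 nM and 25000 nM. The expected step is a 2.5-fold higher number from compound 1 to compound 4 (0.40 log units; beyond the scatter).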

Compound 4, half-maximal effective concentration: 336 nM
The estimate for compound 4 lay 24-fold (1.38 log units) above the measured number; measured number below the stated range.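

For the compounds shown here, at this aromatic carbon, the earlier compounds showed only replacements of 1,3-thiazol-2-yl that raised the number, whereas 1H-pyrazol-5-yl gives a 9.5-fold lower number from compound 1 to compound 4 (0.98 log units; beyond the scatter) in this assay, so the same position can also move the number down. The two groups are both five-membered aromatic rings with two hetero atoms, and they differ in that a nitrogen stands in place of the sulfur and that 1H-pyrazol-5-yl carries a hydrogen-bond donor, which shows that a change this small can matter here, though not which of these differences counts. Against the other two groups the gap is wider, at an at least 29-fold lower number from compound 3 to compound 4 (1.47 log units; beyond the scatter) and an at least 29-fold lower number from compound 2 to compound 4 (1.47 log units; beyond the scatter), and both of these sizes are open-ended for one reason: the limit of > 10000 nM in this assay, at which 2 of the 4 values shown sit.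

As far as these compounds go, whether the hydrogen-bond donor of 1H-pyrazol-5-yl is what lowers the number stays open, and a pyrazole with a methyl group on that ring nitrogen at the same carbon would test this directly. Also open, from the compounds shown here alone, is how far the number can fall at this position, for instance with an imidazole ring or an aminomethyl group there.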